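Aryl-for-bromo analogues: estimate for the methoxyphenyl compound

This account rests on a few compounds, and the source may have more. Where it says the series, first, only, none or still open, it means among the compounds named here.

Values in a functional assay on SF-268 cells (Homo sapiens) for inhibition, read by sulforhodamine B assay, with a stated time of 48 h, tested at 10 uM; on this read-out lower numbers stand for less inhibition and higher numbers for more inhibition at the one concentration tested (going by the name of the read-out):

Compound 1 `Brc1cn2ccnc2c(-c2ccc3ncn(C4CCCCC4)c3c2)n1`: 17.1%
Compound 2 `c1ccc(-c2cn3ccnc3c(-c3ccc4ncn(C5CCCCC5)c4c3)n2)cc1`: 21.7%
Compound 3 `Fc1ccc(-c2cn3ccnc3c(-c3ccc4ncn(C5CCCCC5)c4c3)n2)cc1`: 10.7%

Compound 2 stands highest of the three numbers, but only compound 3 sits beyond the scatter from it: a number 4.6 percentage points higher from compound 1 to compound 2 (within the scatter), whereas a number 11 percentage points lower from compound 2 to compound 3 (beyond the scatter). Neither replacement of bromo by an aryl group moved the read-out beyond the scatter, as a number 6.4 percentage points lower from compound 1 to compound 3 (within the scatter) also shows.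

Compound 4 `COc1ccccc1-c1cn2ccnc2c(-c2ccc3ncn(C4CCCCC4)c3c2)n1` differs from compound 2 in one place: methoxy in place of hydrogen on an aromatic carbon. Among the measured compounds shown here, the one measured step that bears on a substituent added to that phenyl ring is the fluoro step, which gave a number 11 percentage points lower from compound 2 to compound 3 (beyond the scatter), a modest loss. A methoxy group is a different substituent at a different place, so that step is only a loose guide; the three aryl compounds altogether span a narrow band in this assay.

Compound 4 is therefore expected to land near compound 2, with at most a small downward shift: a number 4.7 percentage points lower from compound 2 to compound 4 (within the scatter) is the estimated step. The estimate for compound 4 in this assay is 17%, within a range of 5% to 30%.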

Compound 4, a percentage reported as inhibition, at one concentration (the size of the read-out at that concentration, not a potency): 8.04%
Compound 4: middle estimate off by 9 percentage points, on the high side; the range from low to high includes it.
By their numbers in this assay, from the lowest: compounds 4, 3, 1 and 2 (each within the scatter of the next, the first and the last beyond it).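

In this assay, methoxy on an aromatic carbon of the phenyl ring, ortho to a large group, gives a number 13.7 percentage points lower from compound 2 to compound 4 (beyond the scatter), so both substituted phenyl compounds shown now lie beyond the scatter from compound 2, which carries the unsubstituted phenyl. The two substituted compounds cannot be told apart, with a number 2.7 percentage points lower from compound 3 to compound 4 (within the scatter), although their substituents and substitution places differ. The 2-methoxyphenyl replacement of bromo gives a number 9.1 percentage points lower from compound 1 to compound 4 (within the scatter), so none of the three aryl groups shown moves the read-out beyond the scatter from the bromo compound.

Open, from the compounds shown here alone, is whether an amine or a carboxylic acid on this phenyl ring would stay with compounds 3 and 4 or reach the level of compound 2. No measurement at hand accounts for these steps.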